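The source may report more compounds than this note shows. Statements on the series, on what has been measured and on what is new or still open speak of the compounds shown alone.

Compound 1 `CCC(=O)N(C)c1ccc2[nH]c(-c3n[nH]c4ccccc34)cc2n1`: in a functional assay on A549 cells (Homo sapiens) for antiproliferative activity, read by MTT assay, with a stated time of 72 h (a higher number here means a weaker inhibitor, a lower number a stronger inhibitor), compound 1 gives 15700 nM. Compound 2 `CN(c1ccc2[nH]c(-c3n[nH]c4ccccc34)cc2n1)S(=O)(=O)c1ccc(Cl)cc1`: compound 2 gives 18200 nM.

Compound 2 shows the highest of the two numbers; its nearest neighbour is compound 1, and the step of a 1.2-fold higher number from compound 1 to compound 2 (0.06 log units; within the scatter) lies within the scatter. Compound 3 `COc1ccc(OC)c(S(=O)(=O)N(C)c2ccc3[nH]c(-c4n[nH]c5ccccc45)cc3n2)c1` differs from compound 2 by 2,5-dimethoxyphenyl in place of 4-chlorophenyl on a sulfonyl sulfur. For the measured compounds named here, no measured step alters the group on the sulfonyl sulfur; the one measured step, a 1.2-fold higher number from compound 1 to compound 2 (0.06 log units; within the scatter), exchanged the whole group on the nitrogen and stayed within the scatter. For compound 3 the expected step is therefore a 1.0-fold lower number from compound 2 to compound 3 (0.00 log units; within the scatter), not beyond the scatter. Compound 3 is estimated at 18000 nM, with a range from 7000 nM to 45000 nM.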

Compound 3, half-maximal inhibitory concentration: 19400 nM
For compound 3 the middle estimate is 1.1-fold (0.03 log units) below the measured one; the measured number falls inside the stated range.
By their numbers in this assay, from the lowest: compounds 1, 2 and 3 (each within the scatter of the next).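

On the sulfonyl sulfur, 2,5-dimethoxyphenyl in place of 4-chlorophenyl gives a 1.1-fold higher number from compound 2 to compound 3 (0.03 log units; within the scatter) in this assay and so stays within the scatter. At this position, then, the two aryl groups cannot be told apart in this assay, although the entering group brings 2 hydrogen-bond acceptors and more heavy atoms. No supporting measurement bears on this result.

Open, from the compounds shown here alone, is whether any group on the sulfonyl sulfur moves the number beyond the scatter, for example a small alkyl such as methyl, or a phenyl ring carrying an amine or a carboxylic acid.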